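From 4-Hydroxybenzyl to 3-Cyanobenzyl: Tolerance in Cells

A few compounds are considered here, and "the series" means these few. Any claim that something is new, unique, unknown or untested is made for them only; others in the source may bear on it.

Among the compounds with values here, in a functional assay on MT4 cells (Homo sapiens) for cytotoxicity, read by MTT assay (a higher number here means that more compound is tolerated, a lower number that less compound is tolerated), compound 1 `Cc1c(O)nc(SCc2ccc(O)cc2)nc1Cc1c(Cl)cccc1Cl` gives 41000 nM as the only true number available so far. For compound 2 `Cc1c(O)nc(SCc2ccc(C(C)C)cc2)nc1Cc1c(F)cccc1F` the result of > 62000 nM is a limit and not a number.

Compound 3 `Cc1c(O)nc(SCc2cccc(C#N)c2)nc1Cc1c(Cl)cccc1Cl` has not yet been measured. Within the data shown here, it keeps the core of compound 1 and carries 3-cyanophenyl in place of 4-hydroxyphenyl on a saturated chain carbon bound to a sulfur as its single change. Among the measured compounds shown here, no measured pair shows what a change of this kind does in this assay and the expectation therefore has little to rest on. The estimated 1.2-fold higher number from compound 1 to compound 3 (0.07 log units; within the scatter) is expected to stay within the usual scatter in either direction. This expectation takes compound 1 with its 41000 nM as the starting point. Compound 3 is expected at 48000 nM with an estimated range from 18000 nM to 110000 nM when it is measured.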

Compound 3, half-maximal cytotoxic concentration: > 60000 nM
Compound 3 ended at the assay's limit; the forecaster's own chance of this, stated with the estimate: 40%; middle value at least 1.2-fold (0.09 log units) from the limit.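

Within the data shown here, this pair gives the first reading of a change on a saturated chain carbon bound to a sulfur, with the rest of the core of compound 1 held fixed: in this assay the swap gives an at least 1.4-fold higher number from compound 1 to compound 3 (0.16 log units; that floor lies within the scatter). That step is only a floor because compound 3 sits at a limit of the assay and not at a number: the limit of > 60000 nM in this assay, at which 1 of the 3 values shown sits. So replacing 4-hydroxyphenyl with 3-cyanophenyl does not bring the number down here, yet the floor is too small to establish a true rise.

Going by these compounds, how far compound 3 lies beyond its limit remains open, and so does the comparison with compound 2, which differs from compound 3 in more than one place. Also open, on these data alone, is whether an amine or a carboxylic acid in place of the nitrile would be tolerated equally well.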